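Thiophen-2-yl to phenyl: a step starting from a limit

A few compounds are considered here, and "the series" means these few. Any claim that something is new, unique, unknown or untested is made for them only; others in the source may bear on it.

Measured so far:
compound 1 `Cn1cccc1-c1cc(-c2cccs2)nc(N)c1C#N` — > 100000 nM
compound 2 `Cn1cccc1-c1cc(-c2cccs2)[nH]c(=O)c1C#N` — > 100000 nM

In a functional assay on CCRF-CEM cells (Homo sapiens) for inhibition, read by sulforhodamine B assay, with a stated time of 48 h (a higher number here means a weaker inhibitor of growth, a lower number a stronger inhibitor of growth), compound 1 gives only a limit, > 100000 nM, not a number. Compound 2 likewise stops at a limit, > 100000 nM. Among the compounds with values here, compound 1 therefore stands at the limit of > 100000 nM in this assay, at which 2 of the 2 values shown sit, and no measured compound here lies anywhere else; the two values show no difference between compound 1 and compound 2.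

Compound 3 `Cn1cccc1-c1cc(-c2ccccc2)nc(N)c1C#N` carries phenyl in place of thiophen-2-yl on an aromatic carbon. Within the data shown here, no step between measured compounds is available, so the effect of this change cannot be read from the series itself; both measured values sit at the same limit and give no anchor inside the measurable range.

The expected step in this assay is a number no higher from compound 1 to compound 3 (the limit leaves the size open), none beyond the scatter, with the measurement most likely returning only a limit again. Compound 3 is estimated at 100000 nM, in a range from 30000 nM to 300000 nM.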

Compound 3, concentration for 50% growth inhibition: 80 nM
Compound 3: middle estimate off by 1300-fold (3.10 log units), on the high side, outside the stated range (below it).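

In this assay, phenyl in place of thiophen-2-yl on the aromatic carbon next to the ring nitrogen gives an at least 1200-fold lower number from compound 1 to compound 3 (3.09 log units; beyond the scatter). Compound 1 and compound 2 could not show that this position responds at all, and compound 3 now gives the series a number inside the measurable range, with its step read against a limit. The other values stay at one limit: the limit of > 100000 nM in this assay, at which 2 of the 3 values shown sit.

As far as these compounds go, whether a pyridin-2-yl ring, a furan-2-yl ring or a phenyl bearing a methoxy group at this position would keep the potency of compound 3 remains open. What the amino group and the 1-methyl-1H-pyrrol-2-yl group contribute alongside phenyl is also unresolved.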